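Chloro to Bromo on a Shared Aminothiophene Amide Core

The source may hold more compounds than are shown below. What is called first, only, known or untested is meant among the compounds shown, and "the series" means these compounds.

Compound 1 `Nc1sc(-c2ccccc2)cc1C(=O)NCCCCc1ccccc1`: >= 50000 nM
Compound 2 `CCCCNC(=O)c1cc(CC)sc1N`: >= 50000 nM
Compound 3 `CCCCNC(=O)c1cc(-c2ccc(Cl)cc2)sc1N`: >= 50000 nM

Three compounds sharing the core of compound 1 were tested in an assay on isolated protein for inhibition of Polyunsaturated fatty acid lipoxygenase ALOX15 (Homo sapiens), read by spectrophotometry, with a stated time of 10 min; on this read-out lower numbers stand for stronger inhibition and higher numbers for weaker inhibition. Compound 1 gives only a limit of the assay, >= 50000 nM. Compound 2 likewise gives only a limit, >= 50000 nM. Compound 3, the starting point here, also gives only a limit, >= 50000 nM. Within the data shown here, none of the three provides a number, so no step between measured compounds can be sized; all three sit at the limit of >= 50000 nM in this assay, at which 3 of the 3 values shown sit.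

Compound 4 `CCCCNC(=O)c1cc(-c2ccc(Br)cc2)sc1N` is not yet measured. It differs from compound 3 by bromo in place of chloro on an aromatic carbon. Among the measured compounds shown here, with compound 3 at the limit and no measured step to lean on, the change is expected to produce no step beyond the scatter, and compound 4 is expected to stay at the limit as well. The step from compound 3 to compound 4 is thus estimated as a number no higher from compound 3 to compound 4 (the limit leaves the size open). Compound 4 is accordingly estimated at 50000 nM, within a range from 25000 nM to 100000 nM.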

Compound 4, half-maximal inhibitory concentration: >= 50000 nM
Compound 4: a limit, no number; the forecaster's own chance of this, stated with the estimate: 85%; the middle value lies on the limit itself.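

Compound 3 and compound 4 both give only limits, so no step can be read for bromo in place of chloro on an aromatic carbon: the limit of >= 50000 nM in this assay, at which 4 of the 4 values shown sit. The compounds shown leave open which change to the shared core, if any, would give a measured number rather than a limit.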